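From Bromomethyl to Fluoromethyl: One Halogen Exchanged

The compounds below may be only part of what the source reports. "The series", "measured", "known", "first", "only" and "open" are said of these compounds alone.

Of the compounds shown here, two have so far been measured in a functional assay on L1210 cells (Mus musculus) for inhibition; on this read-out higher numbers stand for weaker inhibition and lower numbers for stronger inhibition. There compound 1 (`Cc1ccc(S(=O)(=O)OC[C@H]2OC(n3cc(F)c(=O)[nH]c3=O)[C@H](O)[C@@H]2O)cc1`) gives 460 nM, and compound 2 (`O=c1[nH]c(=O)n(C2O[C@H](CBr)[C@@H](O)[C@H]2O)cc1F`) gives 800 nM. These two numbers lie within the usual scatter of each other, so compound 2 cannot be separated from compound 1 on this evidence.

Compound 3 (`O=c1[nH]c(=O)n(C2O[C@H](CF)[C@@H](O)[C@H]2O)cc1F`) has not yet been measured. It departs from compound 2 by a single exchange, fluoro in place of bromo on a saturated chain carbon bound to a saturated ring carbon, turning bromomethyl into fluoromethyl. Among the measured compounds shown here, no measured pair here differs in one place only, so the data offer no direct guide to the size of such a step. For the measured compounds named here, the only hint is that compound 1, at 460 nM, and compound 2, at 800 nM, stay within the scatter although their structures differ. No step beyond the scatter is therefore expected in this assay, in either direction. The estimated step is a 1.1-fold higher number from compound 2 to compound 3 (0.05 log units; within the scatter). For compound 3 the expected value is 900 nM, with an estimated range from 300 nM to 3000 nM.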

Compound 3, half-maximal inhibitory concentration: 29000 nM
The estimate for compound 3 lay 32-fold (1.51 log units) below the measured number; measured number outside the range, above it.
By their numbers in this assay, from the lowest: compounds 1 and 2 (each within the scatter of the next); then compound 3.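

In this assay, fluoro in place of bromo on a saturated chain carbon bound to a saturated ring carbon gives a 36-fold higher number from compound 2 to compound 3 (1.56 log units; beyond the scatter), a large step beyond the scatter and the first single-place change read here. This position is therefore not indifferent to which halogen it carries, and the bromomethyl of compound 2 gives far stronger inhibition than the fluoromethyl of compound 3, although only one heavy atom is exchanged and the counts of rings, hydrogen-bond donors, hydrogen-bond acceptors and net charge stay the same on both sides. No measurement shown here bears on why the exchange has so large an effect.

The compounds shown leave open whether chloro or iodo on the same carbon would read like bromo or like fluoro, so it cannot yet be said whether fluoro is the exception or whether the read-out follows the series of halogens. They also leave open how a hydroxyl, an amine or a plain methyl in that place would compare with compound 2 and compound 3.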